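A few compounds are considered here, and "the series" means these few. Any claim that something is new, unique, unknown or untested is made for them only; others in the source may bear on it.

The series shares one core, carried by compound 1 `COc1cccc(C(=O)NCCNC(=O)[C@H](CC(=O)NC(C)(C)C)NS(=O)(=O)c2ccc(C)cc2)c1`, compound 2 `Cc1ccc(S(=O)(=O)N[C@@H](CC(=O)NC(C)(C)C)C(=O)NCCNC(=O)c2ccccc2F)cc1` and compound 3 `Cc1ccc(S(=O)(=O)N[C@@H](CC(=O)NC(C)(C)C)C(=O)NCCNC(=O)c2ccccn2)cc1`, which differ only in the aromatic group on a carbonyl carbon. In an ADME assay on Karpas-1106P cells (Homo sapiens) for cytotoxicity (on this read-out lower numbers stand for an effect already at smaller amounts and higher numbers for an effect only at larger amounts of compound), compound 1 gives > 11100 nM, a limit of the assay rather than a number. In this assay compound 2 gives > 11100 nM, likewise only a limit. In this assay compound 3 gives > 11100 nM, again a limit. Because every value sits at the limit of > 11100 nM in this assay, at which 3 of the 3 values shown sit, the steps a step that the two limits leave unreadable from compound 1 to compound 2, a step that the two limits leave unreadable from compound 1 to compound 3 and a step that the two limits leave unreadable from compound 2 to compound 3 cannot be read in size. Compound 4 `Cc1ccc(S(=O)(=O)N[C@@H](CC(=O)NC(C)(C)C)C(=O)NCCNC(=O)c2cccc(C(F)(F)F)c2)cc1` has not yet been measured; its change from compound 2 is 3-(trifluoromethyl)phenyl in place of 2-fluorophenyl on a carbonyl carbon. The measured steps bear on it only in that none of the aromatic exchanges so far moved a value off the limit. The account therefore expects no step beyond the scatter in this assay, with compound 4 estimated at 15000 nM (range 8000 nM to 40000 nM), an expected step that the limit leaves unreadable from compound 2 to compound 4.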

Compound 4, half-maximal effective concentration: > 11100 nM
Compound 4 gave a limit, no number; the forecaster's own chance of this, stated with the estimate: 85%; the middle value lies beyond the limit too.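

In this assay compound 4 gives > 11100 nM, again a limit and not a number. Its steps to compound 1, compound 2 and compound 3 therefore cannot be read in size: the limit of > 11100 nM in this assay, at which 4 of the 4 values shown sit.

The compounds shown leave open whether any aromatic group on this carbonyl carbon would give a number in this assay.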